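The source may hold more compounds than are shown below. What is called first, only, known or untested is meant among the compounds shown, and "the series" means these compounds.

In an ADME assay on Huh-7 cells (Homo sapiens) for cytotoxicity (on this read-out lower numbers stand for higher toxicity in this test and higher numbers for lower toxicity in this test), compound 2 `Cc1ccccc1-c1nn(-c2ccc(F)cc2)cc1CNCCN1CCN(C)CC1` gives > 20000 nM, which is a limit of the assay and not a number. Compound 1 `Cc1ccccc1-c1nn(-c2ccc(F)cc2F)cc1CNCCN1CCCCC1` in this assay gives > 20000 nM, again a limit. Compound 3 `Cc1ccccc1-c1nn(-c2ccc(F)cc2F)cc1CNCCCN1CCN(C)CC1` in this assay gives > 20000 nM, also a limit. Among the measured compounds shown here, the one step between measured compounds that differ in a single place, a step that the two limits leave unreadable from compound 1 to compound 3, therefore cannot be read, and all the three values show is the limit of > 20000 nM in this assay, at which 3 of the 3 values shown sit.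

Compound 4 `Cc1ccccc1-c1nn(-c2ccc(OC(F)(F)F)cc2)cc1CNCCN1CCN(C)CC1` has not yet been measured. It differs from compound 2 by trifluoromethoxy in place of fluoro on an aromatic carbon, a change that, cut one bond further out, reads 4-fluorophenyl to 4-(trifluoromethoxy)phenyl. For the measured compounds named here, no measured step touches this aromatic carbon, so none bears on it directly; the three values merely agree that nothing has yet given a number inside the measured window of this assay. Compound 4 is therefore expected to sit at the same limit, meaning an expected step that the limit leaves unreadable from compound 2 to compound 4, within the scatter. Compound 4 is estimated at 25000 nM, with a range from 10000 nM to 60000 nM.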

Compound 4, half-maximal cytotoxic concentration: 17000 nM
Compound 4: the middle estimate sits 1.5-fold (0.17 log units) above what was measured, and the stated range covers the measured number.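

In this assay compound 4 gives 17000 nM, the first value among the compounds shown that is a number and not a limit, so this aromatic carbon is the only place so far where a change has led to a readable value. Trifluoromethoxy in place of fluoro gives an at least 1.1-fold lower number from compound 2 to compound 4 (0.07 log units; that floor lies within the scatter), so this change cannot yet be told apart from the scatter, and its real size may be larger. The other compounds offer no number to set beside it: the limit of > 20000 nM in this assay, at which 3 of the 4 values shown sit.

The compounds shown leave open how far the value of compound 2 lies from that of compound 4, and whether a methoxy or a trifluoromethyl group on this aromatic carbon would also give a number. They also leave open whether trifluoromethoxy would do so alongside the piperidine of compound 1 or the longer chain of compound 3.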